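Removing the methoxy group: what happens to the cytotoxicity readout

The source may hold more compounds than are shown below. What is called first, only, known or untested is meant among the compounds shown, and "the series" means these compounds.

Measured compounds:
compound 1 `CCOC(=O)/C=C/c1ccc(OC(=O)c2nc(C)c(C)nc2C)c(O)c1` gives 211%
compound 2 `CCOC(=O)/C=C/c1ccc(OC(=O)c2nc(C)c(C)nc2C)c(OC)c1` gives 69.7%

Of the two compounds measured in a functional assay on EA.hy 926 cells (Homo sapiens) for cytotoxicity, read by MTT assay, with stated times of 24 h and 12 h, tested at 50 uM (a higher number here means a stronger effect of the compound at the concentration tested, a lower number a weaker effect), compound 2 stands lowest. Its nearest neighbour is compound 1, and the step of a number 141.3 percentage points lower from compound 1 to compound 2 (beyond the scatter) is large. The unmeasured compound 3 `CCOC(=O)/C=C/c1ccc(OC(=O)c2nc(C)c(C)nc2C)cc1` differs from compound 2 in one place: hydrogen in place of methoxy on an aromatic carbon. Among the measured compounds shown here, the only measured step touches the same oxygen on the aromatic ring, but it describes methyl entering in place of hydrogen there, not the loss of the whole methoxy group, so it bears on the new step only indirectly: it shows that this part of the molecule can move the readout strongly. For the measured compounds named here, with no closer precedent, the step from compound 2 to compound 3 in this assay is expected to stay within the scatter, though with wide uncertainty, so the estimated step is a number 0.3 percentage points higher from compound 2 to compound 3 (within the scatter). Compound 3 is therefore estimated at 70%, within a range of 35% to 130%.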

Compound 3, a percentage reported as activity, at one concentration (the size of the read-out at that concentration, not a potency): 62.6%
Beside the measured number, compound 3's estimate is 7.4 percentage points above it, within the range that was stated.
By their numbers in this assay, from the lowest: compounds 3 and 2 (each within the scatter of the next); then compound 1.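

Hydrogen in place of methoxy on this aromatic carbon cannot be told apart from the scatter in this assay, with a number 7.1 percentage points lower from compound 2 to compound 3 (within the scatter). Hydrogen in place of hydroxy on the same carbon gives a number 148.4 percentage points lower from compound 1 to compound 3 (beyond the scatter), so among these compounds the high readout is found only with the free hydroxy group, while methoxy and hydrogen read alike. Nothing available here accounts for this difference.

On these data alone, whether an amine or a longer chain such as ethoxy on this carbon would read like the hydroxy group or like the methoxy group stays open. Also open, as far as these compounds go, is whether the high readout of the hydroxy compound would survive a carboxylic acid in place of the ethyl ester of the 2-(ethoxycarbonyl)ethenyl group.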